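Fluorinated stilbenes: nitro for hydroxy on the methoxy ring

This account rests on a few compounds, and the source may have more. Where it says the series, first, only, none or still open, it means among the compounds named here.

Compound 1 `COc1ccc(/C(F)=C\c2cc(OC)c(OC)c(OC)c2)cc1O` is the reference of this set. In a functional assay on NCI-H460 cells (Homo sapiens) for cytotoxicity, read by sulforhodamine B assay, with a stated time of 72 h (a lower number here means a stronger inhibitor, a higher number a weaker inhibitor), compound 1 gives 4 nM. Compound 2 `COc1ccc(/C(F)=C\c2cc(OC)c(OC)c(OC)c2)cc1[N+](=O)[O-]` carries the change (nitro in place of hydroxy on an aromatic carbon); in this assay compound 2 gives 379 nM. Among the measured compounds shown here, the step of a 95-fold higher number from compound 1 to compound 2 (1.98 log units; beyond the scatter) is the only measured step for this change in the set. It is a large loss of potency.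

Compound 3 `COc1ccc(/C(F)=C(/F)c2cc(OC)c(OC)c(OC)c2)cc1O` shares the core of compound 1, but the difference between the two cores is not broken down here. In this assay compound 3 gives 3 nM, which lies within the scatter of compound 1 and far from compound 2.

Compound 4 `COc1ccc(/C(F)=C(/F)c2cc(OC)c(OC)c(OC)c2)cc1[N+](=O)[O-]` is not yet measured. Relative to compound 3 it carries nitro in place of hydroxy on an aromatic carbon, the same change that turns compound 1 into compound 2, in the same surroundings. For the measured compounds named here, the measured step of a 95-fold higher number from compound 1 to compound 2 (1.98 log units; beyond the scatter) is the only guide, and a step of similar size is expected here. The estimated step for compound 4 is a 100-fold higher number from compound 3 to compound 4 (2.00 log units; beyond the scatter). Compound 4 is therefore expected to give about 300 nM in this assay, with a plausible span from 100 nM to 900 nM. Going by the values given here, only one occurrence of the change has been measured, so the expectation rests on a single pair.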

Compound 4, half-maximal inhibitory concentration: 1170 nM
Compound 4: middle estimate off by 3.9-fold (0.59 log units), on the low side, and the stated range ends below it.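

In this assay, nitro in place of hydroxy gives a 390-fold higher number from compound 3 to compound 4 (2.59 log units; beyond the scatter), so the direction of the change carries over from the core of compound 1 to the core of compound 3, and the loss is large on both. The size does not carry over unchanged, and the step on one core is not a close numerical guide to the step on the other: the same change on two cores in this assay, a 95-fold higher number (1.98 log units; beyond the scatter) from compound 1 to compound 2 and a 390-fold higher number (2.59 log units; beyond the scatter) from compound 3 to compound 4, 4.1-fold (0.61 log units) apart, beyond the scatter of two such steps

Among the compounds shown here, with only one pair on each core, these data do not show which difference between the two cores goes with the wider gap, nor whether a gap of this kind would recur on a further core or with another replacement.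

On these data alone, what an amine or a carboxylic acid on this aromatic carbon would give remains open, as does whether the low numbers of compound 1 and compound 3 depend on hydroxy itself or only on the absence of nitro. Also open, as far as these compounds go, is whether the two steps would keep their relative size on a core bearing a chlorine or a methyl group on the bond between the two aromatic rings.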